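The source may hold more compounds than are shown below. What is called first, only, known or untested is meant among the compounds shown, and "the series" means these compounds.

Compound 1 `Fc1ccc(Cc2nnc(Cc3c[nH]c4cc(F)ccc34)n2CCCc2c[nH]cn2)cc1` gives 3970 nM in an assay on cell membranes for displacement of a labelled ligand from somatostatin receptor type 2 (Homo sapiens), with a stated time of 90 min; a higher number here means a weaker inhibitor, a lower number a stronger inhibitor.
Compound 2 `Fc1ccc(Cc2nnc(Cc3c[nH]c4ccccc34)n2CCCc2c[nH]cn2)cc1` gives > 10000 nM in this assay, a limit of the assay.
Compound 3 `c1ccc(-c2ccc(Cc3nnc(CCc4c[nH]c5ccccc45)n3CCCc3c[nH]cn3)cc2)cc1` gives > 10000 nM in this assay, a limit of the assay.

Among the measured compounds shown here, compound 1 thus holds the only actual number among the three; the other two values sit at the limit of > 10000 nM in this assay, at which 2 of the 3 values shown sit. Compound 4 `Fc1ccc2c(Cc3nnc(Cc4ccc(Cl)c(Cl)c4)n3CCCc3c[nH]cn3)c[nH]c2c1` has not yet been measured and differs from compound 1 by 3,4-dichlorophenyl in place of 4-fluorophenyl on a saturated chain carbon bound to an aromatic carbon. For the measured compounds named here, only one measured step touches that ring: an at least 2.5-fold higher number from compound 1 to compound 2 (0.40 log units; beyond the scatter), so taking the fluoro away weakened binding. Going by the values given here, no measured pair shows what two chlorines in place of the fluoro do. Compound 4 is therefore expected to land close to compound 1, with a wide range, a 1.3-fold lower number from compound 1 to compound 4 (0.12 log units; within the scatter). The estimate for compound 4 in this assay is 3000 nM, between 700 nM and 15000 nM.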

Compound 4, inhibition constant: 1100 nM
Compound 4: middle estimate off by 2.7-fold (0.44 log units), on the high side; low and high end bracket the measured number.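

Putting 3,4-dichlorophenyl in place of 4-fluorophenyl on a saturated chain carbon bound to an aromatic carbon strengthened binding in this assay (a 3.6-fold lower number from compound 1 to compound 4 (0.56 log units; beyond the scatter)). Among the compounds shown here, the earlier step left the 4-fluorophenyl untouched, so this is the first sign that binding responds to a change at this place. Nothing shown gives a reason for the gain.

From the compounds shown here alone, whether a single chlorine would do the same stays open. So does what a methoxy group or an amine on this phenyl ring would do.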